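Sulfonamide ring exchange on compound 1

This account rests on a few compounds, and the source may have more. Where it says the series, first, only, none or still open, it means among the compounds named here.

In a functional assay on SF-268 cells (Homo sapiens) for antiproliferative activity, read by sulforhodamine B assay, with a stated time of 72 h (on this read-out higher numbers stand for weaker inhibition and lower numbers for stronger inhibition), compound 1 `O=S(=O)(Nc1nccs1)c1ccc(Nc2nncc3ccccc23)cc1` gives 45 nM and compound 2 `COc1ccc(NC(=S)NNc2nncc3ccccc23)cc1` gives 86 nM on the same read-out. For the measured compounds named here, these two values lie within the usual scatter of each other, so compound 1 stands level with the only other measured compound. Going by the values given here, no measured step that differs in one place links them, and the series offers no direct precedent for the change considered here.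

Compound 3 `Cc1cc(NS(=O)(=O)c2ccc(Nc3nncc4ccccc34)cc2)no1` keeps the rest of compound 1 and carries 5-methyl-1,2-oxazol-3-yl in place of 1,3-thiazol-2-yl on a sulfonamide nitrogen. Both groups are five-membered aromatic rings. The expectation therefore starts from compound 1 at 45 nM and has no measured exchange to adjust it. No shift beyond the scatter is expected in this assay, and the estimated step of a 1.3-fold higher number from compound 1 to compound 3 (0.12 log units; within the scatter) is small and leans, if at all, toward weaker inhibition. For compound 3 the expected value is 60 nM, with an estimated range from 20 nM to 180 nM on this read-out.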

Compound 3, half-maximal inhibitory concentration: 24 nM
Beside the measured number, compound 3's estimate is 2.5-fold (0.40 log units) above it; the range from low to high includes it.
By their numbers in this assay, from the lowest: compounds 3, 1 and 2 (each within the scatter of the next, the first and the last beyond it).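

In this assay the exchange of 1,3-thiazol-2-yl for 5-methyl-1,2-oxazol-3-yl on a sulfonamide nitrogen amounts to a 1.9-fold lower number from compound 1 to compound 3 (0.27 log units; within the scatter) and leaves the two compounds level. For the compounds shown here, this is the first one-place step, and it shows that the sulfur-bearing ring is not required on this nitrogen to hold the read-out at this level: a five-membered aromatic ring carrying oxygen and a methyl group serves equally well here. No measurement at hand explains the result or gives a property of either ring.

Going by these compounds, the step changes the ring and adds the methyl group together, so the share of each stays open, and unsubstituted 1,2-oxazol-3-yl on the same nitrogen would separate them. Also open, on these data alone, is how far this position tolerates change beyond five-membered aromatic rings, for instance to pyridin-2-yl, pyrimidin-2-yl or a plain acetyl group on the sulfonamide nitrogen.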